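What a butyl swap may do to compound 1

The compounds below may be only part of what the source reports. "The series", "measured", "known", "first", "only" and "open" are said of these compounds alone.

compound 1 `CC(C)C(=O)OCOC(=O)N1CCN(C(=O)c2nc(Nc3cc(C4CC4)[nH]n3)c3cc(Cl)ccc3n2)C[C@H]1C` gives 93.5% 
compound 2 `CC(OC(=O)N1CCN(C(=O)c2nc(Nc3cc(C4CC4)[nH]n3)c3cc(Cl)ccc3n2)C[C@H]1C)OC(=O)C(C)(C)C` gives 90.5% 
compound 3 `C[C@@H]1CN(C(=O)c2nc(Nc3cc(C4CC4)[nH]n3)c3cc(Cl)ccc3n2)CCN1C(=O)OCc1ccccc1` gives 97.7% 

All three values come from a physicochemical assay, read by HPLC, in phosphate buffer, with a stated time of 2 h, at pH 7.4 (a higher number here means that more of the compound is left, a lower number that less of the compound is left), and lie close together. The nearest neighbour of compound 1 shows a number 3 percentage points lower from compound 1 to compound 2 (within the scatter) and its furthest neighbour shows a number 4.2 percentage points higher from compound 1 to compound 3 (within the scatter) (both small steps). The remaining pair shows a number 7.2 percentage points higher from compound 2 to compound 3 (within the scatter) (also a small step). Compound 1 therefore sits in a tight group with no clear order.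

Compound 4 `CCCCCOC(=O)N1CCN(C(=O)c2nc(Nc3cc(C4CC4)[nH]n3)c3cc(Cl)ccc3n2)C[C@H]1C` has not been measured yet. Its difference from compound 1 is butyl in place of (isopropylcarbonyl)oxy on a saturated chain carbon bound to an oxygen next to a carbonyl group. Cut one bond further out, the same change reads ((isopropylcarbonyl)oxy)methyl to pentyl.

Among the measured compounds shown here, the closest precedent is compound 3 at 97.7% (it carries phenyl in place of (isopropylcarbonyl)oxy at the same place). Its step from compound 1 stayed small, and so did the change on the same oxygen that leads to compound 2 at 90.5% (a different replacement). No step beyond the scatter is therefore expected, and the expected change is a number 1.5 percentage points higher from compound 1 to compound 4 (within the scatter) (an estimate). Compound 4 is estimated at 95% (expected range 87% to 100%).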

Compound 4, percent of the compound remaining: 99.8%
Estimate against measurement, compound 4: 4.8 percentage points below; the range from low to high includes it.
By their numbers in this assay, from the lowest: compounds 2, 1, 3 and 4 (each within the scatter of the next).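

In this assay, replacing (isopropylcarbonyl)oxy with butyl on a saturated chain carbon bound to an oxygen next to a carbonyl group gives a number 6.3 percentage points higher from compound 1 to compound 4 (within the scatter), so a chain with no ring and no hydrogen-bond acceptors joins the phenyl of compound 3 among the replacements that stay within the scatter. The two other new steps tell the same story: butyl in place of phenyl gives a number 2.1 percentage points higher from compound 3 to compound 4 (within the scatter), and pentyl in place of 1-(((tert-butyl)carbonyl)oxy)ethyl on the oxygen gives a number 9.3 percentage points higher from compound 2 to compound 4 (within the scatter), which is the largest of the three new steps and still does not leave the scatter. No measurement available here explains why these numbers fall as they do.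

As far as these compounds go, whether an amine, a carboxylic acid or a chain longer than pentyl on the same oxygen would move the number beyond the scatter stays open. From the compounds shown here alone, with all four compounds so close together, it also remains unknown whether any replacement at this position can separate clearly from compound 1 in this assay at all.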